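A few compounds are considered here, and "the series" means these few. Any claim that something is new, unique, unknown or untested is made for them only; others in the source may bear on it.

Compound 1 `COc1ccccc1OC(C)(C)C1OCC(C/C=C\CCC(=O)O)C(c2cccnc2)O1`: 224 nM
Compound 2 `CSc1ccccc1OC(C)(C)C1OCC(C/C=C\CCC(=O)O)C(c2cccnc2)O1`: 89.1 nM
Compound 3 `COc1ccc(OC(C)(C)C2OCC(C/C=C\CCC(=O)O)C(c3cccnc3)O2)c([N+](=O)[O-])c1`: 6.17 nM

These three compounds were measured in a functional assay for inhibition, with Homo sapiens as the target; a lower number here means tighter binding, a higher number weaker binding. Compound 2, at 89.1 nM, holds the middle of the three numbers: a 2.5-fold lower number from compound 1 to compound 2 (0.40 log units; beyond the scatter), while a 14-fold lower number from compound 2 to compound 3 (1.16 log units; beyond the scatter).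

Compound 4 `Cc1ccc(SC(C)(C)C2OCC(C/C=C\CCC(=O)O)C(c3cccnc3)O2)c([N+](=O)[O-])c1` has not yet been measured. Its difference from compound 2 lies on a saturated chain carbon bound to two saturated chain carbons and a saturated ring carbon: a group of 11 heavy atoms (7 carbon, 1 nitrogen, 2 oxygen, 1 sulfur; one six-membered aromatic ring of carbon only) in place of a group of 9 heavy atoms (7 carbon, 1 oxygen, 1 sulfur; one six-membered aromatic ring of carbon only), on a saturated chain carbon bound to two saturated chain carbons and a saturated ring carbon. The 2-(methylsulfanyl)phenoxy group leaves.

The best guides are the two large steps to compound 3, a 36-fold lower number from compound 1 to compound 3 (1.56 log units; beyond the scatter) and a 14-fold lower number from compound 2 to compound 3 (1.16 log units; beyond the scatter). Among the compounds with values here, compound 3 is the only measured compound with a nitro group, and compound 4 carries one too. However, compound 4 also differs from compound 3 elsewhere in the entering group, and no measured step tests those differences. A large step to a lower number is therefore expected, though probably not quite the full step seen for compound 3.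

The expected change is a 7.4-fold lower number from compound 2 to compound 4 (0.87 log units; beyond the scatter).

For compound 4, the estimated value is 12 nM, with an expected range of 3 nM to 45 nM.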

Compound 4, dissociation constant: 158 nM
For compound 4 the middle estimate is 13-fold (1.12 log units) below the measured one; the measured number lies above the stated range.
By their numbers in this assay, from the lowest: compound 3; then compounds 2, 4 and 1 (each within the scatter of the next, the first and the last beyond it).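

Carrying a nitro group on the aromatic ring is not enough on its own to give a low number at this position: compound 4 has one, yet it sits level with compound 2 (a 1.8-fold higher number from compound 2 to compound 4 (0.25 log units; within the scatter)) and with compound 1 (a 1.4-fold lower number from compound 1 to compound 4 (0.15 log units; within the scatter)). The low value of compound 3 (6.17 nM) therefore cannot be credited to the nitro group alone, and compound 4 also differs from it in having sulfur rather than oxygen joining ring to chain, and methyl rather than methoxy on the ring. The data shown offer no measured explanation for this result.

Which of those two differences matters remains open, as they change together here. So does whether an amine or a chlorine in place of the nitro group would behave alike.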